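The compounds below may be only part of what the source reports. "The series", "measured", "known", "first", "only" and "open" are said of these compounds alone.

Measured compounds:
- compound 1 `COc1cc(C)cc(-c2c(-c3ccnc(-c4ccc(C(C)=O)cc4)c3)cnn2CC#N)c1` — 5880 nM
- compound 2 `COc1cc(C)cc(-c2nn(CC#N)cc2-c2ccnc(-c3ccc(N(C)C)cc3)c2)c1` — 1010 nM

Both values come from a functional assay on SK-MEL-2 cells (Homo sapiens) for inhibition, read by sulforhodamine B assay, with a stated time of 48 h; on this read-out higher numbers stand for weaker inhibition of growth and lower numbers for stronger inhibition of growth. Compound 1 gives 5880 nM and stands with the highest number of the two. Its nearest neighbour is compound 2, which gives 1010 nM, a lower number lying beyond the usual scatter. The two differ in more than one place, so the gap between them is noted only as what the two values show.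

Compound 3 `COc1cc(C)cc(-c2c(-c3ccnc(-c4ccc(N(C)C)cc4)c3)cnn2CC#N)c1` is not yet measured in this assay. It differs from compound 1 in one place: dimethylamino in place of acetyl on an aromatic carbon. For the measured compounds named here, no step between measured compounds isolates this single change. Compound 2, however, carries the same dimethylamino-substituted phenyl on a related core and gives 1010 nM, a lower number than compound 1 gives with 5880 nM. A step toward a lower number, beyond the scatter, is therefore expected for compound 3, with the estimated step of a 3.7-fold lower number from compound 1 to compound 3 (0.57 log units; beyond the scatter). Compound 3 is expected to give about 1600 nM, within roughly 500 nM to 5000 nM.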

Compound 3, concentration for 50% growth inhibition: 204 nM
Compound 3: middle estimate off by 7.8-fold (0.89 log units), on the high side; the whole stated range lies above it.
By their numbers in this assay, from the lowest: compound 3; then compound 2; then compound 1.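

In this assay, for the compounds shown here, dimethylamino in place of acetyl on an aromatic carbon, para to a large group, gives a 29-fold lower number from compound 1 to compound 3 (1.46 log units; beyond the scatter) and is the first single-change step. The result therefore shows that this position is highly sensitive to the group it carries, which the earlier comparison of compound 1 and compound 2 could not show because those compounds differ in more than one place. Both groups count 3 heavy atoms and the same hydrogen-bond donors and acceptors, and no available measurement bears on the cause of the step.

From the compounds shown here alone, it remains open whether the step depends on the two methyl groups on the nitrogen, which a primary amine, a morpholine or a methoxy group in the same place on the shared core would help to separate. An acetyl counterpart of compound 2 would test whether the same change gives a step of similar size on that core.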